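The compounds below may be only part of what the source reports. "The series", "measured", "known", "first", "only" and "open" are said of these compounds alone.

Going by the values given here, only two compounds have been tested so far in a functional assay on UACC-62 cells (Homo sapiens); on this read-out lower numbers stand for stronger inhibition of growth and higher numbers for weaker inhibition of growth. Compound 1 `O=S(=O)(/C=C/c1ccc(Br)cc1)Cc1ccc(Nc2ncnc3ccccc23)cc1` gives > 100000 nM, which is a limit of the assay and not a true number. Among the compounds with values here, compound 2 `O=S(=O)(/C=C/c1ccc(Cl)c(Cl)c1)Cc1ccc(Nc2ncnc3ccc(Br)cc23)cc1` gives 30000 nM, so it stands as the only compound here with an actual number, and that number is the sole reference point for what follows.

Compound 3 `O=S(=O)(/C=C/c1ccc(Br)cc1)Cc1ccc(Nc2ncnc3ccc(Br)cc23)cc1` has not yet been measured. It keeps the structure of compound 2 apart from one change: 4-bromophenyl in place of 3,4-dichlorophenyl on a double-bonded chain carbon bound to a double-bonded chain carbon. In words, 4-bromophenyl takes the place of 3,4-dichlorophenyl on a double-bonded chain carbon bound to a double-bonded chain carbon. Within the data shown here, no measured pair of compounds shows what this kind of swap does. One aromatic ring of carbon only is replaced by another, so the expectation is no step beyond the usual scatter in this assay, starting from the 30000 nM of compound 2. The expected change is no change at the digits printed from compound 2 to compound 3 (within the scatter). For compound 3 the estimated value is 30000 nM, with an expected range from 10000 nM to 100000 nM.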

Compound 3, concentration for 50% growth inhibition: > 100000 nM
Compound 3 ended at the assay's limit (the forecaster's own chance of this, stated with the estimate: 25%); middle value at least 3.3-fold (0.52 log units) from the limit.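

In this assay, putting 4-bromophenyl in place of 3,4-dichlorophenyl on a double-bonded chain carbon bound to a double-bonded chain carbon gives an at least 3.3-fold higher number from compound 2 to compound 3 (0.52 log units; beyond the scatter), which means weaker inhibition of growth and shows that the group at this place matters, even though one carbon-only aromatic ring simply replaces another. From the compounds shown here alone, compound 3 gives > 100000 nM, which is a limit of the assay and not a true number, so the real size of this step remains unknown. The step from compound 1 to compound 3, bromo in place of hydrogen on an aromatic carbon, cannot be read, and the effect of that change stays hidden at the edge of what the assay can report: the limit of > 100000 nM in this assay, at which 2 of the 3 values shown sit.

The compounds shown leave open which part of the swap counts, since the ring's substituents differ both in the halogen present and in their number, and 4-chlorophenyl at this place would help to separate the two. They also leave open whether a quite different group on this ring, such as an amine or a carboxylic acid, would give stronger inhibition of growth than compound 2 does.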